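A few compounds are considered here, and "the series" means these few. Any claim that something is new, unique, unknown or untested is made for them only; others in the source may bear on it.

In a functional assay on HL-60 cells (Homo sapiens) for antiproliferative activity, with a stated time of 72 h (on this read-out lower numbers stand for stronger inhibition and higher numbers for weaker inhibition), compound 1 `OC[C@H]1O[C@@H](n2cnc3c(NCc4ccccc4F)ncnc32)[C@H](O)[C@@H]1O` gives 3200 nM and compound 2 `OC[C@H]1O[C@@H](n2cnc3c(NCc4ccc(F)cc4)ncnc32)[C@H](O)[C@@H]1O` gives 1200 nM while compound 3 `OC[C@H]1O[C@@H](n2cnc3c(NCc4ccccc4Cl)ncnc32)[C@H](O)[C@@H]1O` gives 1600 nM on the same scale. Compound 3 cannot be told apart from either of the other two: the data show a 1.3-fold higher number from compound 2 to compound 3 (0.12 log units; within the scatter) and also a 2.0-fold lower number from compound 1 to compound 3 (0.30 log units; within the scatter) and neither gap exceeds ordinary repeat variation. Only a 2.7-fold lower number from compound 1 to compound 2 (0.43 log units; beyond the scatter) stands clear of that variation.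

Compound 4 `OC[C@H]1O[C@@H](n2cnc3c(NCc4ccc(Cl)cc4)ncnc32)[C@H](O)[C@@H]1O` has the same atoms as compound 3, joined differently: 4-chlorophenyl in place of 2-chlorophenyl on a saturated chain carbon bound to a nitrogen on an aromatic ring with 4-chlorophenyl in place of 2-chlorophenyl on a saturated chain carbon bound to a nitrogen on an aromatic ring. For the measured compounds named here, the closest precedent is the fluorine pair, where the same change of group position gave a 2.7-fold lower number from compound 1 to compound 2 (0.43 log units; beyond the scatter) as its result. That is a single modest step, and it was seen with fluoro rather than chloro. Going by the values given here, no measured pair tests the change with chloro itself, so the precedent has to be carried across with caution. A modest step toward a lower number is therefore expected in this assay for this change. The estimated change is a 2.3-fold lower number from compound 3 to compound 4 (0.36 log units; beyond the scatter) by this reasoning. The expected value for compound 4 is 700 nM within an estimated range of 300 nM to 1600 nM in this test.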

Compound 4, half-maximal inhibitory concentration: 1700 nM
For compound 4 the middle estimate is 2.4-fold (0.39 log units) below the measured one; the whole stated range lies below it.
By their numbers in this assay, from the lowest: compounds 2, 3, 4 and 1 (each within the scatter of the next, the first and the last beyond it).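

In this assay, moving the chlorine from 2-chlorophenyl to 4-chlorophenyl does not repeat what the same move did with fluorine: the fluoro pair showed a 2.7-fold lower number from compound 1 to compound 2 (0.43 log units; beyond the scatter), whereas the chloro pair shows a 1.1-fold higher number from compound 3 to compound 4 (0.03 log units; within the scatter), so at this place the position of the chlorine makes no readable difference. For the compounds shown here, the other two new steps are also small, with a 1.4-fold higher number from compound 2 to compound 4 (0.15 log units; within the scatter) for chloro in place of fluoro and a 1.9-fold lower number from compound 1 to compound 4 (0.27 log units; within the scatter) for the change of both atom and position, so compound 4 cannot be told apart from any of the earlier compounds. What the earlier compounds could not show is that the swap of fluoro for chloro does not read the same at the two positions, even though neither step alone stands clear of the scatter: the same change on two cores in this assay, a 2.0-fold lower number (0.30 log units; within the scatter) from compound 1 to compound 3 and a 1.4-fold higher number (0.15 log units; within the scatter) from compound 2 to compound 4, 2.8-fold (0.45 log units) apart, beyond the scatter of two such steps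

Going by these compounds, whether bromo or methoxy at these two positions would behave like fluoro or like chloro remains open. So does the effect of a longer chain in place of the 4-chlorobenzyl group on the shared core.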